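A few compounds are considered here, and "the series" means these few. Any claim that something is new, unique, unknown or untested is made for them only; others in the source may bear on it.

In a functional assay on MDA-MB-231 cells (Homo sapiens) for inhibition, read by MTT assay, with a stated time of 48 h (a lower number here means a stronger inhibitor, a higher number a weaker inhibitor), three compounds sharing one core have been measured. Compound 1 `COc1ccc(N(C)c2nc(C)nc3ccccc23)cc1C(=O)NCC[Se]C#N` gives 1250 nM and compound 2 `COc1ccc(N(C)c2nc(C)nc3ccccc23)cc1C(=O)OCCCC[Se]C#N` gives 554 nM while compound 3 `COc1ccc(N(C)c2nc(C)nc3ccccc23)cc1[Se]C#N` gives 52 nM as the lowest number of the three, which makes it the strongest inhibitor of this small set.

Compound 4 `COc1ccc(N(C)c2nc(C)nc3ccccc23)cc1OCCCCC[Se]C#N` has not yet been measured. Its difference from compound 3 is a group of 9 heavy atoms (6 carbon, 1 nitrogen, 1 oxygen, 1 selenium; no ring) in place of a group of 3 heavy atoms (1 carbon, 1 nitrogen, 1 selenium; no ring), on an aromatic carbon and it sits on an aromatic carbon of a six-membered aromatic ring of carbon only, ortho to a methoxy group. Put simply, a longer chain takes the place of the small selenium group.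

Compound 1 and compound 2 also carry longer selenium-bearing groups, so they are the closest guides. The steps of a 24-fold lower number from compound 1 to compound 3 (1.38 log units; beyond the scatter) and an 11-fold lower number from compound 2 to compound 3 (1.03 log units; beyond the scatter) were both large, whereas the step of a 2.3-fold lower number from compound 1 to compound 2 (0.35 log units; beyond the scatter) between the two longer groups was only modest. Neither of them joins its chain through an ether oxygen as compound 4 does, so this comparison is loose.

For compound 4 a large step toward a higher number, meaning a weaker inhibitor, is therefore expected in this assay as the estimated 9.6-fold higher number from compound 3 to compound 4 (0.98 log units; beyond the scatter) for this change. The estimate for compound 4 is 500 nM with an expected range from 150 nM to 1500 nM in this measurement.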

Compound 4, half-maximal inhibitory concentration: 4410 nM
Compound 4: middle estimate off by 8.8-fold (0.95 log units), on the low side; measured number above the stated range.
By their numbers in this assay, from the lowest: compound 3; then compound 2; then compound 1; then compound 4.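

In this assay, for the compounds shown here, replacing the small selenium group on this aromatic carbon with the longer chain joined through an ether oxygen gives the largest step at this position so far (an 85-fold higher number from compound 3 to compound 4 (1.93 log units; beyond the scatter)), so compound 4 is a much weaker inhibitor than compound 3. This chain also does worse than both longer selenium-bearing groups joined through a carbonyl (an 8.0-fold higher number from compound 2 to compound 4 (0.90 log units; beyond the scatter) and a 3.5-fold higher number from compound 1 to compound 4 (0.55 log units; beyond the scatter)), which shows that a long group here does not settle at one level and that the number moves further with the change in the group's link and length, leaving compound 4 the weakest of the four. No measurement shown here explains this loss of activity.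

Compound 4 differs from compound 1 and compound 2 in both its linking atoms and its chain length, so the compounds shown cannot separate the effect of the ether oxygen from that of the length. A shorter chain on the same ether oxygen, or an amine in place of that oxygen with the chain kept unchanged, would help to tell these two apart.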